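Swapping the amine on a dithiocarbamate benzamide

A few compounds are considered here, and "the series" means these few. Any claim that something is new, unique, unknown or untested is made for them only; others in the source may bear on it.

The measured compounds:
- compound 1, `CN(C(=S)SCc1ccc(C(=O)Nc2ccccc2N)cc1)c1cccnc1`: 16%
- compound 2, `N#Cc1ccc(N2CCN(C(=S)SCc3ccc(C(=O)Nc4ccccc4N)cc3)CC2)cc1`: 71.6%
- compound 3, `Nc1ccccc1NC(=O)c1ccc(CSC(=S)N(Cc2ccccc2)Cc2ccccc2)cc1`: 1%

All three share one core, a dithiocarbamate linked to a benzamide, and differ only in the amine attached to the thiocarbonyl carbon. In a functional assay on HeLa cells (Homo sapiens) for antiproliferative activity, read by CCK-8 assay, with a stated time of 72 h, tested at 2 uM (on this read-out higher numbers stand for a stronger effect at the one concentration tested and lower numbers for a weaker effect), compound 1 gives 16%, which places it second highest of the three numbers. Compound 3 sits lower, at 1%, a gap that goes beyond the usual scatter. Compound 2 sits far higher, at 71.6%, again beyond the scatter. Among the compounds with values here, the amine at the thiocarbonyl carbon therefore matters, but with only three examples no rule can be drawn from them.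

Compound 4, `Nc1ccccc1NC(=O)c1ccc(CSC(=S)N2CCCC2)cc1`, has not yet been measured in this assay. It differs from compound 1 in one place: pyrrolidin-1-yl in place of methyl(pyridin-3-yl)amino on a thiocarbonyl carbon. Within the data shown here, no measured pair shows a change of this kind, so the direction of the step is open. The small saturated ring of compound 4 is unlike either the arylpiperazine of compound 2 or the dibenzylamino group of compound 3, and the low values of compound 1 at 16% and compound 3 at 1% suggest that only some amines bring strong effect. Compound 4 is therefore expected to stay near compound 1, with a step of a number 2 percentage points higher from compound 1 to compound 4 (within the scatter) that need not exceed the scatter. Compound 4 is estimated at 18%, within a range of 2% to 50%.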

Compound 4, a percentage reported as inhibition, at one concentration (the size of the read-out at that concentration, not a potency): 51.3%
Compound 4: the middle estimate sits 33.3 percentage points below what was measured; the measured number lies above the stated range.
By their numbers in this assay, from the lowest: compound 3; then compound 1; then compound 4; then compound 2.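

In this assay, within the data shown here, putting pyrrolidin-1-yl in place of methyl(pyridin-3-yl)amino on a thiocarbonyl carbon gives a number 35.3 percentage points higher from compound 1 to compound 4 (beyond the scatter), the first step that can be read at this position. It shows that a single change of amine on the shared core can shift the read-out well beyond the usual scatter, and that compound 4 reaches 51.3% with a small saturated ring and with no aromatic ring in the amine at all. Nothing shown here explains why this swap raises the number, so the step stands as an observation only.

Going by these compounds, what remains open is which feature of the pyrrolidin-1-yl group matters, since this one step changes the ring, the number of heavy atoms and the pyridine nitrogen all at once. A piperidin-1-yl group, a morpholin-4-yl group or an open-chain diethylamino group at the same place would help separate these features, and a full concentration series would be needed to show how the effect changes beyond the one concentration tested.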